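Two dopamine receptor agonists and an untested dichlorophenyl analogue

This account rests on a few compounds, and the source may have more. Where it says the series, first, only, none or still open, it means among the compounds named here.

Two compounds have been characterised in a functional assay on HEK293 cells for agonist activity at D(4) dopamine receptor (Homo sapiens), read by FLIPR; on this read-out higher numbers stand for an effect only at larger amounts of compound and lower numbers for an effect already at smaller amounts. Compound 1 `O=C(CN1CCC(c2cccc[n+]2[O-])CC1)Nc1cccc(F)c1` gives 160 nM in this assay. Compound 2 `C=Cc1cccc(C(=O)NCN2CCC(c3cccc[n+]3[O-])CC2)c1` gives 68 nM in this assay, the lower of the two numbers; the gap to compound 1 is wider than the usual scatter of repeated measurements, though the two compounds differ in more than one place, so no single change can be held responsible for it.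

Compound 3 `O=C(NCN1CCC(c2cccc[n+]2[O-])CC1)c1cc(Cl)cc(Cl)c1` has not yet been measured in this assay. It differs from compound 2 in one place: 3,5-dichlorophenyl in place of 3-vinylphenyl on a carbonyl carbon. No comparable single change has been measured among the compounds described here, so the expectation for this step rests on general experience with such amide-side aryl replacements rather than on a measured precedent. The step from compound 2 to compound 3 is expected to be small, of the order of the scatter or only a little beyond it, and its direction is uncertain; the expected step is a 1.1-fold lower number from compound 2 to compound 3 (0.05 log units; within the scatter). Compound 3 is therefore estimated to give 60 nM in this assay, within a range from 20 nM to 200 nM.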

Compound 3, half-maximal effective concentration: 45 nM
For compound 3 the middle estimate is 1.3-fold (0.12 log units) above the measured one; the measured number falls inside the stated range.
By their numbers in this assay, from the lowest: compounds 3 and 2 (each within the scatter of the next); then compound 1.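

In this assay, for the compounds shown here, the first single-place change reads as a 1.5-fold lower number from compound 2 to compound 3 (0.18 log units; within the scatter) on the carbonyl carbon whose other neighbour is the amide-type nitrogen. This position therefore accepts 3,5-dichlorophenyl in place of 3-vinylphenyl with no change beyond the scatter, so a ring carrying two chlorines and a ring carrying a vinyl group cannot be told apart on this read-out. No measurement at hand says why the two groups read alike.

Still open, on these data alone, is how this same carbonyl position answers to groups of another kind, such as a pyridine ring, a cyclohexyl ring, or a phenyl ring bearing a carboxylic acid or an amine, as both groups seen here are aromatic rings of carbon only. Also open, as far as these compounds go, is how the difference between compound 1 and the other two divides among its several changes, which a 3-fluorophenyl group on the carbonyl carbon of compound 2's chain would begin to separate.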